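A few compounds are considered here, and "the series" means these few. Any claim that something is new, unique, unknown or untested is made for them only; others in the source may bear on it.

Measured compounds:
- compound 1, `NC1=NC2(CCSCC2)N(OCCCOc2ccc(Br)cc2)C(N)=N1` — "not determined" (no result reported) in an assay on isolated protein for inhibition of Dihydrofolate reductase (Homo sapiens), read by spectrophotometry, using NADPH, with stated times of 5 s and 6 min, tested at 50 uM; a higher number here means a stronger effect of the compound at the concentration tested, a lower number a weaker effect
- compound 2, `Cc1cc(C)cc(OCCCON2C(N)=NC(N)=NC23CCOCC3)c1` — 88.6%
- compound 3, `NC1=NC2(CCSCC2)N(OCCCOc2cccc(Cl)c2Cl)C(N)=N1` — 89.8%

Compound 3 carries the higher of the two numbers available in this assay, yet the gap to compound 2 lies within the usual scatter of such repeated measurements, so the two results cannot be told apart on the evidence. Compound 1 adds no number. Among the compounds with values here, with only two values at hand, both of them high and close together, the series so far says nothing about how a change on the aryl end moves the read-out.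

Compound 4, `NC1=NC2(CCSCC2)N(OCCCOc2ccccc2Br)C(N)=N1`, differs from compound 3 in one place: 2-bromophenyl in place of 2,3-dichlorophenyl on an oxygen on a saturated carbon

Within the data shown here, no step between measured compounds is available to calibrate this change. Given that compound 2 and compound 3, which carry quite different aryl groups, both land near the top of the scale, the expectation is that compound 4 will also lie in that region, and the estimated step of a number 4.8 percentage points lower from compound 3 to compound 4 (within the scatter) is small, most likely within the scatter, with any drift more probably downward than upward. Compound 4 is therefore estimated at 85% in this assay, within a range from 70% to 95%.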

Compound 4, a percentage reported as inhibition, at one concentration (the size of the read-out at that concentration, not a potency): 89.6%
Beside the measured number, compound 4's estimate is 4.6 percentage points below it; measured number inside the range.
By their numbers in this assay, from the lowest: compounds 2, 4 and 3 (each within the scatter of the next).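

In this assay, within the data shown here, putting 2-bromophenyl in place of 2,3-dichlorophenyl on an oxygen on a saturated carbon gives a number 0.2 percentage points lower from compound 3 to compound 4 (within the scatter) and is the first comparison of compounds that differ in one place. At this position, then, the read-out does not separate a phenyl ring with two chlorine atoms from one with a single bromine atom, despite the change from 8 to 7 heavy atoms in the group, though a single-concentration percentage is no measure of potency and any potency difference would remain unseen here. Nothing available explains why this exchange leaves the read-out unresolved.

Still open, going by these compounds, is whether this tolerance extends beyond halogen-bearing phenyl groups at this position, for example to a phenyl ring carrying an amine or a carboxylic acid. Among these compounds, also open is how the read-out responds to a longer chain in place of the present saturated chain, and whether the shared core can be changed without loss of effect, since no one-place step yet addresses either part of the structure.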